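The source may report more compounds than this note shows. Statements on the series, on what has been measured and on what is new or still open speak of the compounds shown alone.

Measured compounds in the series:

Compound 1 `CCCCCCCCCCCCn1nnc(C(NC(=O)c2ccc(F)cc2F)c2ccccc2)n1`; in an assay on microsomes from liver for inhibition of sterol O-acyltransferase 1 (Rattus norvegicus) (a lower number here means a stronger inhibitor, a higher number a weaker inhibitor), compound 1 gives 490 nM.
Compound 2 `CCCCCCCCCCCCn1nnc(C(NC(=O)c2ccccc2)c2ccccc2)n1`; compound 2 gives 350 nM.
Compound 3 `CCCCCCCCCCCCn1nnc(C(NC(=O)c2ccc(Cl)cc2)c2ccccc2)n1`; compound 3 gives 440 nM.

Compound 3 stands second highest of the three numbers. Its nearest neighbour is compound 1, the furthest compound 2, and both gaps are within the scatter: a 1.1-fold lower number from compound 1 to compound 3 (0.05 log units; within the scatter) and a 1.3-fold higher number from compound 2 to compound 3 (0.10 log units; within the scatter). The three compounds share one core and differ only in the substitution of the aromatic ring on the carbonyl carbon; a 1.4-fold lower number from compound 1 to compound 2 (0.15 log units; within the scatter) shows that removing both fluorines also stays within the scatter. On these numbers the benzoyl substituent has not moved the read-out in a resolvable way.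

The next compound is compound 4 `CCCCCCCCCCCCn1nnc(C(NC(=O)c2ccc(C)cc2)c2ccccc2)n1`. Its change from compound 3 is methyl in place of chloro on an aromatic carbon. The step that bears most directly on it is a 1.3-fold higher number from compound 2 to compound 3 (0.10 log units; within the scatter), where placing a chloro on the same aromatic carbon left the number within the scatter. Exchanging that chloro for a methyl is therefore expected to give no step beyond the scatter, a 1.1-fold lower number from compound 3 to compound 4 (0.04 log units; within the scatter). For compound 4 the estimate in this assay is 400 nM, with a range of 200 nM to 800 nM.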

Compound 4, half-maximal inhibitory concentration: 510 nM
For compound 4 the middle estimate is 1.3-fold (0.11 log units) below the measured one; low and high end bracket the measured number.
By their numbers in this assay, from the lowest: compounds 2, 3, 1 and 4 (each within the scatter of the next).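

Three occupants of the aromatic carbon para to a large group can now be compared: hydrogen, chloro and methyl. In this assay, exchanging chloro for methyl gives a 1.2-fold higher number from compound 3 to compound 4 (0.06 log units; within the scatter), and methyl in place of hydrogen gives a 1.5-fold higher number from compound 2 to compound 4 (0.16 log units; within the scatter), so a methyl at this position, the first occupant in the series that is not a halogen, is not resolved from either chloro or hydrogen. The wider exchange on the carbonyl carbon gives a 1.0-fold higher number from compound 1 to compound 4 (0.02 log units; within the scatter), and no evidence bears on this result.

The compounds shown hold only hydrogen, halogens and methyl on this ring, so it stays open whether an amine, a carboxylic acid or a methoxy group at the same carbon would produce a step beyond the scatter. From the compounds shown here alone, all four compounds also carry the same dodecyl chain and the same unsubstituted phenyl on the shared core, so what a shorter chain or a substituted phenyl would do in this assay remains unknown.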